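This account rests on a few compounds, and the source may have more. Where it says the series, first, only, none or still open, it means among the compounds named here.

Measured in a functional assay on HeLa cells (Homo sapiens) for cytotoxicity, read by MTT assay; a higher number here means a weaker inhibitor, a lower number a stronger inhibitor:
Compound 1 `C[C@H]1[C@H](O)C[C@@H](CCO)N[C@H]1c1ccccc1` gives 31500 nM.
Compound 2 `C[C@H]1[C@H](O)C[C@@H](CC(=O)O)N[C@H]1c1ccccc1` gives 33400 nM.
Compound 3 `COc1ccc([C@H]2N[C@@H](CCO)C[C@H](O)[C@H]2C)cc1` gives 16500 nM.

Compound 4 `COc1ccc([C@H]2N[C@@H](CC(=O)O)C[C@H](O)[C@H]2C)cc1` has not yet been measured. It differs from compound 3 in one place: carboxy in place of hydroxymethyl on a saturated chain carbon bound to a saturated ring carbon. The same change separates compound 1 from compound 2: carboxy in place of hydroxymethyl on a saturated chain carbon bound to a saturated ring carbon. In both pairs the place is described in the same words, so this is the same change, made on two different cores; how the core of compound 1 differs from the core of compound 3 is not broken down here. In this assay the measured pair shows a 1.1-fold higher number from compound 1 to compound 2 (0.03 log units; within the scatter), so the change left the number essentially where it was. Between compound 3 and compound 1 the gap is within the scatter, between compound 3 and compound 2 it lies beyond it. Since the same change is now made once more, the step is expected to be small again: a 1.1-fold higher number from compound 3 to compound 4 (0.03 log units; within the scatter) is the estimated step, resting on a 1.1-fold higher number from compound 1 to compound 2 (0.03 log units; within the scatter). Compound 4 is therefore expected to give about 17500 nM, with a likely range from 9000 nM to 35000 nM.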

Compound 4, half-maximal inhibitory concentration: 19900 nM
Compound 4: middle estimate off by 1.1-fold (0.06 log units), on the low side; measured number inside the range.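

In this assay, putting carboxy in place of hydroxymethyl on the core of compound 3 gives a 1.2-fold higher number from compound 3 to compound 4 (0.08 log units; within the scatter), so here too the change leaves the number essentially where it was. Set side by side, the two steps do not differ, and the change carries over from one core to the other in this series: the same change on two cores in this assay, a 1.1-fold higher number (0.03 log units; within the scatter) from compound 1 to compound 2 and a 1.2-fold higher number (0.08 log units; within the scatter) from compound 3 to compound 4, 1.1-fold (0.06 log units) apart, within the scatter of two such steps. Going by these compounds alone, this rests on only two pairs and one cell assay, so it does not show that the change would stay just as small on other cores or in other assays, and it does not explain why the number barely moves.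

The compounds shown carry only 2-hydroxyethyl or carboxymethyl in this place, so it remains open what an amine, an amide, a methyl ester or a longer chain would do there. Also open, going by these compounds, is whether any such group would move the number beyond the scatter on either core.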